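The source may hold more compounds than are shown below. What is called first, only, known or untested is meant among the compounds shown, and "the series" means these compounds.

Measured so far in a functional assay on HCT-116 cells (Homo sapiens) for inhibition, read by sulforhodamine B assay, with a stated time of 72 h; on this read-out higher numbers stand for weaker inhibition and lower numbers for stronger inhibition: compound 1 `CC(c1ccc(-c2ccccc2)c(F)c1)c1nnc2n1N=C(c1ccc(OC(F)(F)F)cc1)CS2` gives 5400 nM; compound 2 `CC(c1ccc(-c2ccccc2)c(F)c1)c1nnc2n1N=C(c1ccc(Cl)cc1)CS2` gives 7800 nM; compound 3 `CC(c1ccc(-c2ccccc2)c(F)c1)c1nnc2n1N=C(c1ccc(F)cc1)CS2` gives 10500 nM.

Compound 3 stands highest of the three numbers, but its steps to the other two are small: a 1.3-fold higher number from compound 2 to compound 3 (0.13 log units; within the scatter) and a 1.9-fold higher number from compound 1 to compound 3 (0.29 log units; within the scatter) both lie within the scatter, as does a 1.4-fold higher number from compound 1 to compound 2 (0.16 log units; within the scatter). All three measured steps concern the same aromatic carbon and exchange trifluoromethoxy, chloro and fluoro among themselves, and none moves the number beyond the scatter.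

Compound 4 `Cc1ccc(C2=Nn3c(nnc3C(C)c3ccc(-c4ccccc4)c(F)c3)SC2)cc1` differs from compound 3 by methyl in place of fluoro on an aromatic carbon. For the measured compounds named here, no measured step shows a methyl at this position, so the nearest guide is the set of exchanges already seen there, all of which stayed within the scatter. On that basis no step beyond the scatter is expected in this assay for compound 4, in either direction: the expected step is a 1.2-fold lower number from compound 3 to compound 4 (0.07 log units; within the scatter). The estimate for compound 4 is 9000 nM, with an expected range from 4000 nM to 20000 nM.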

Compound 4, half-maximal inhibitory concentration: 4800 nM
Beside the measured number, compound 4's estimate is 1.9-fold (0.27 log units) above it, and the stated range covers the measured number.
By their numbers in this assay, from the lowest: compounds 4, 1, 2 and 3 (each within the scatter of the next, the first and the last beyond it).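

In this assay, for the compounds shown here, the change from 4-fluorophenyl to 4-methylphenyl gives the first step at this position that lies beyond the scatter, though only a modest one (a 2.2-fold lower number from compound 3 to compound 4 (0.34 log units; beyond the scatter)). Going by these compounds alone, the other two exchanges for methyl stay within the scatter (a 1.6-fold lower number from compound 2 to compound 4 (0.21 log units; within the scatter)) and (a 1.1-fold lower number from compound 1 to compound 4 (0.05 log units; within the scatter)), so the methyl and fluoro pair is the only pair of these groups that the assay separates, while chloro and trifluoromethoxy remain unresolved from methyl. Nothing available accounts for this step.

On these data alone, how an amine, a carboxylic acid or a longer chain in this place on the aromatic ring would read remains open. Also open, as far as these compounds go, is whether the methyl and fluoro difference holds when other parts of the shared core change.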